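The source may report more compounds than this note shows. Statements on the series, on what has been measured and on what is new or still open speak of the compounds shown alone.

Compound 1 `Cc1cnc(Nc2ccc(N3CCN(C)CC3)c(F)c2)nc1-c1ccc(F)c(Cl)c1` gives 2800 nM in an assay on isolated protein for inhibition of tyrosine-protein kinase receptor UFO (Homo sapiens), read by TR-FRET, with a stated time of 60 min; on this read-out lower numbers stand for stronger inhibition and higher numbers for weaker inhibition.
Compound 2 `Cc1cnc(Nc2ccc(CN3CCN(C)CC3)cc2)nc1-c1ccc(F)cc1S(=O)(=O)N1CCCC1` gives 2930 nM in this assay.
Compound 3 `CN1CCN(Cc2ccc(Nc3ncc(Cl)c(Nc4ccccc4S(=O)(=O)N4CCCC4)n3)cc2)CC1` gives 19 nM in this assay.

Compound 3 stands lowest of the three numbers in this assay; compound 1 and compound 2 both lie far above it, each beyond the usual scatter. Compound 4 `CN1CCN(Cc2ccc(Nc3ncc(Cl)c(Nc4ccc(F)cc4S(=O)(=O)N4CCCC4)n3)cc2)CC1` differs from compound 3 by fluoro in place of hydrogen on an aromatic carbon. Within the data shown here, no step between measured compounds matches this change, so no direction can be drawn from the data themselves. The change is expected to move this assay only a little, with no step beyond the scatter: a 1.1-fold higher number from compound 3 to compound 4 (0.02 log units; within the scatter). Compound 4 is therefore estimated at 20 nM, within a range from 8 nM to 50 nM.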

Compound 4, half-maximal inhibitory concentration: 37 nM
For compound 4 the middle estimate is 1.9-fold (0.27 log units) below the measured one, within the range that was stated.
By their numbers in this assay, from the lowest: compounds 3 and 4 (each within the scatter of the next); then compounds 1 and 2 (each within the scatter of the next).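

In this assay, fluoro in place of hydrogen on this aromatic carbon, para to a large group and meta to a (pyrrolidin-1-yl)sulfonyl group, gives a 1.9-fold higher number from compound 3 to compound 4 (0.29 log units; within the scatter), a step within the usual scatter. This position therefore accepts a single fluorine without a readable change in the number. No measurement at hand offers an explanation for this result.

Going by these compounds, whether chloro, methoxy or an amine on the same carbon would also leave the number undisturbed remains open. This single step also cannot tell whether fluoro on other carbons of this ring would behave alike.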